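The source may report more compounds than this note shows. Statements on the series, on what has been measured and on what is new or still open speak of the compounds shown alone.

In a functional assay on cells (KATO III cell, Homo sapiens) for antiproliferative activity, read by MTT assay (a higher number here means a weaker inhibitor, a lower number a stronger inhibitor), compound 1 `O=C1NC(c2ccccc2)CN1S(=O)(=O)c1ccc2c(c1)CCCN2`, which has a hydrogen on the nitrogen of the shared core, gives > 20000 nM, a limit of the assay and not a number. Compound 2 `COC(=O)N1CCCc2cc(S(=O)(=O)N3CC(c4ccccc4)NC3=O)ccc21`, with methoxycarbonyl on that nitrogen, gives 16500 nM. Compound 3 `CCCCOC(=O)N1CCCc2cc(S(=O)(=O)N3CC(c4ccccc4)NC3=O)ccc21`, with butoxycarbonyl there, gives 4010 nM, the lowest number in this small set and so the strongest inhibitor of the three.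

The next structure, compound 4 `C=CCOC(=O)N1CCCc2cc(S(=O)(=O)N3CC(c4ccccc4)NC3=O)ccc21`, keeps everything except the end of that chain, turning butoxycarbonyl into allyloxycarbonyl: vinyl in place of propyl on a saturated chain carbon bound to an oxygen next to a carbonyl group. The most relevant measured change is a 4.1-fold lower number from compound 2 to compound 3 (0.61 log units; beyond the scatter), where propyl replaced hydrogen at this same place and the number fell beyond the scatter. The step from compound 1 points the same way, as an at least 4.9-fold lower number from compound 1 to compound 3 (0.69 log units; beyond the scatter) shows, although it starts from a limit.

Vinyl is smaller than propyl but larger than hydrogen, so compound 4 can be expected to keep part of the gain seen with compound 3, though probably not all of it. Within the data shown here, no measured compound carries a double bond in this chain, which leaves the estimate loose. The expected change is small, a 1.6-fold higher number from compound 3 to compound 4 (0.21 log units; within the scatter), toward a higher number, and it may not clear the scatter. For compound 4 the estimated value is 6500 nM, with an expected range from 3000 nM to 14000 nM.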

Compound 4, half-maximal inhibitory concentration: 5050 nM
Beside the measured number, compound 4's estimate is 1.3-fold (0.11 log units) above it, and the stated range covers the measured number.
By their numbers in this assay, from the lowest: compounds 3 and 4 (each within the scatter of the next); then compound 2. At a limit, above all of these: compound 1.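

Putting vinyl in place of propyl on this saturated chain carbon gives a 1.3-fold higher number from compound 3 to compound 4 (0.10 log units; within the scatter), so in this assay the double bond and the shorter chain leave the number inside the usual scatter of the butoxycarbonyl result. Vinyl in place of hydrogen at the same carbon gives a 3.3-fold lower number from compound 2 to compound 4 (0.51 log units; beyond the scatter), so the gain over methoxycarbonyl, earlier seen only with propyl, also appears with a different and shorter chain end and does not need the saturated butyl chain. Allyloxycarbonyl in place of hydrogen on the nitrogen gives an at least 3.9-fold lower number from compound 1 to compound 4 (0.59 log units; beyond the scatter), which is only a floor, as compound 1 stands at a limit of the assay and not at a number: the limit of > 20000 nM in this assay, at which 1 of the 4 values shown sits.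

The compounds shown stop at butoxycarbonyl, so it stays open whether a longer chain such as hexyloxycarbonyl, or a benzyloxycarbonyl group with its phenyl ring, would lower the number further or whether the gain levels off. On these data alone, it is also open how the chain end would tolerate an amine or a carboxylic acid, since only carbon groups have been placed there so far.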